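Phenyl to pyridyl change on the imine carbon

The source may report more compounds than this note shows. Statements on the series, on what has been measured and on what is new or still open speak of the compounds shown alone.

Within the data shown here, compound 2 `CC(C)(C)CC[C@H](c1ccc(C(=O)NCc2nn[nH]n2)cc1)N1C(=O)C(c2ccc(C(F)(F)F)cc2)=N[C@]12CC[C@@H](C(C)(C)C)CC2` gives 7 nM in an assay on CHO cells for displacement of a labelled ligand from Glucagon receptor (Homo sapiens), read by scintillation counting, with a stated time of 60 min (on this read-out higher numbers stand for weaker inhibition and lower numbers for stronger inhibition), the lower of the two numbers so far, yet within the scatter of compound 1 `CC(C)(C)CC[C@H](c1ccc(C(=O)NCc2nn[nH]n2)cc1)N1C(=O)C(c2cccc(C(F)(F)F)c2)=N[C@]12CC[C@@H](C(C)(C)C)CC2`, which gives 13 nM. Among the measured compounds shown here, the only measured step, a 1.9-fold lower number from compound 1 to compound 2 (0.27 log units; within the scatter), moves the trifluoromethyl on the ring and does not test a ring nitrogen. Compound 3 `CC(C)(C)CC[C@H](c1ccc(C(=O)NCc2nn[nH]n2)cc1)N1C(=O)C(c2cnccc2C(F)(F)F)=N[C@]12CC[C@@H](C(C)(C)C)CC2` carries 4-(trifluoromethyl)pyridin-3-yl in place of 4-(trifluoromethyl)phenyl on a carbon with a double bond to nitrogen. For the measured compounds named here, no measured step bears on this change, so no step beyond the scatter is expected in this assay. Compound 3 is estimated at 10 nM, with a range of 3 nM to 35 nM, a step of a 1.4-fold higher number from compound 2 to compound 3 (0.15 log units; within the scatter).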

Compound 3, half-maximal inhibitory concentration: 22 nM
Compound 3: middle estimate off by 2.2-fold (0.34 log units), on the low side, within the range that was stated.
By their numbers in this assay, from the lowest: compounds 2, 1 and 3 (each within the scatter of the next, the first and the last beyond it).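

In this assay, among these compounds, 4-(trifluoromethyl)pyridin-3-yl in place of 4-(trifluoromethyl)phenyl gives the first step at this position beyond the scatter, a 3.1-fold higher number from compound 2 to compound 3 (0.50 log units; beyond the scatter), though a modest one. Against 3-(trifluoromethyl)phenyl the same group stays within the scatter, at a 1.7-fold higher number from compound 1 to compound 3 (0.23 log units; within the scatter), so the reading depends on which phenyl compound serves as reference. Nothing available here accounts for either step.

Open, on these data alone, is whether other pyridine isomers, or a phenyl bearing a nitrile or a methoxy group in place of trifluoromethyl, would match compound 2.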